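Para-Methoxyphenyl Variant of a Fused Bicyclic 5-HT7 Ligand

The source may report more compounds than this note shows. Statements on the series, on what has been measured and on what is new or still open speak of the compounds shown alone.

Compound 1 `c1ccc(Cn2cc(-c3ccccc3)c3c2CCNC3)cc1`: 220 nM
Compound 2 `Clc1cccc(-c2cn(Cc3ccccc3)c3c2CNCC3)c1`: 10000 nM
Compound 3 `Fc1cccc(-c2cn(Cc3ccccc3)c3c2CNCC3)c1`: 2730 nM

Of the compounds shown here, three sharing one core have been tested in an assay on HEK293 cells for displacement of a labelled ligand from 5-hydroxytryptamine receptor 7 (Rattus norvegicus), with a stated time of 60 min; on this read-out higher numbers stand for weaker inhibition and lower numbers for stronger inhibition. Compound 1 carries an unsubstituted phenyl and gives 220 nM. Compound 3 stands second highest of the three values: in this assay compound 3 gives 2730 nM, a step of a 12-fold higher number from compound 1 to compound 3 (1.09 log units; beyond the scatter), while the chloro analogue compound 2 sits further out, with a 3.7-fold lower number from compound 2 to compound 3 (0.56 log units; beyond the scatter).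

Compound 4 `COc1ccc(-c2cn(Cc3ccccc3)c3c2CNCC3)cc1` differs from compound 3 by 4-methoxyphenyl in place of 3-fluorophenyl on an aromatic carbon. Among the measured compounds shown here, no measured step exchanges the whole aryl group, so the two steps that bear on it are indirect: both measured substituents on the phenyl ring pushed the number up, a 45-fold higher number from compound 1 to compound 2 (1.66 log units; beyond the scatter) and a 12-fold higher number from compound 1 to compound 3 (1.09 log units; beyond the scatter). Nothing measured addresses a methoxy group or substitution at the 4-position of that ring, so the direction of this change is uncertain; a step of modest size is expected, most likely a 1.8-fold lower number from compound 3 to compound 4 (0.26 log units; within the scatter), with a wide range.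

Compound 4 is therefore estimated at 1500 nM in this assay, expected to lie between 300 nM and 8000 nM.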

Compound 4, inhibition constant: 290 nM
The estimate for compound 4 lay 5.2-fold (0.71 log units) above the measured number; the measured number lies below the stated range.
By their numbers in this assay, from the lowest: compounds 1 and 4 (each within the scatter of the next); then compound 3; then compound 2.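

In this assay, a substituent on this phenyl does not always raise the number: 4-methoxyphenyl in place of 3-fluorophenyl gives (a 9.4-fold lower number from compound 3 to compound 4 (0.97 log units; beyond the scatter)), and in place of 3-chlorophenyl it gives (a 34-fold lower number from compound 2 to compound 4 (1.54 log units; beyond the scatter)). Set against the unsubstituted phenyl of compound 1, the methoxy group leaves the number within the scatter (a 1.3-fold higher number from compound 1 to compound 4 (0.12 log units; within the scatter)). Compound 4 therefore goes against what compound 2 and compound 3 had suggested, and it shows that the phenyl at this position can carry a substituent without a step beyond the scatter from compound 1.

Nothing available explains why the methoxy compound reads so differently from the two halogen compounds. Because the exchange alters both the substituent and its place on the ring, the compounds shown cannot separate these two changes, and they leave open how an ethoxy group, an amine or a carboxylic acid on this phenyl would read.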